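This account rests on a few compounds, and the source may have more. Where it says the series, first, only, none or still open, it means among the compounds named here.

Compound 1 `CN1CCN(C2CCN(c3nccc4[nH]c(-c5ccc(F)c(C(F)(F)F)c5)nc34)CC2)CC1`: 4800 nM
Compound 2 `CN1CCN(C2CCN(c3nccc4[nH]c(-c5cc(F)cc(F)c5)nc34)CC2)CC1`: 30000 nM
Compound 3 `CN1CCN(C2CCN(c3nccc4[nH]c(-c5cccc(S(C)(=O)=O)c5)nc34)CC2)CC1`: > 50000 nM (a limit of the assay)

In an ADME assay on CHO cells (Cricetulus griseus) for cytotoxicity, read by MTT assay (a higher number here means that more compound is tolerated, a lower number that less compound is tolerated), compound 2 gives the higher of the two exact numbers, 30000 nM. Compound 3 reports only a limit. Compound 4 `Fc1cc(F)cc(-c2nc3c(N4CCC(CN5CCC(F)(F)CC5)CC4)nccc3[nH]2)c1` keeps the 3,5-difluorophenyl of compound 2 and changes a different place: (4,4-difluoropiperidin-1-yl)methyl in place of 4-methylpiperazin-1-yl on a saturated ring carbon. Among the compounds with values here, no measured step touches that place. Within the data shown here, the only guides are the swaps on the aromatic carbon, a 6.3-fold higher number from compound 1 to compound 2 (0.80 log units; beyond the scatter) and an at least 10-fold higher number from compound 1 to compound 3 (1.01 log units; beyond the scatter), which show only how far numbers can move in this small set. A modest downward step is therefore expected in this assay, though the direction is uncertain. The expected step is a 2.0-fold lower number from compound 2 to compound 4 (0.30 log units; within the scatter). For compound 4 the estimate is 15000 nM, with an expected range from 4000 nM to 50000 nM.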

Compound 4, half-maximal cytotoxic concentration: 26000 nM
The estimate for compound 4 lay 1.7-fold (0.24 log units) below the measured number; the measured number falls inside the stated range.
By their numbers in this assay, from the lowest: compound 1; then compounds 4 and 2 (each within the scatter of the next). At a limit, above all of these: compound 3.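

In this assay, the step is a 1.2-fold lower number from compound 2 to compound 4 (0.06 log units; within the scatter), so compound 2 and compound 4 cannot be told apart. Compounds 1, 2 and 3 differ only on the aromatic carbon, whereas this pair shows that, with 3,5-difluorophenyl kept, (4,4-difluoropiperidin-1-yl)methyl can stand in place of 4-methylpiperazin-1-yl on the saturated ring carbon without a change beyond the scatter. Nothing shown gives a measured reason for this result. Going by these compounds, whether the same holds with the 4-fluoro-3-(trifluoromethyl)phenyl of compound 1 remains open. So does the outcome with a morpholine, an open-chain amine or a carboxylic acid at this place.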